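A few compounds are considered here, and "the series" means these few. Any claim that something is new, unique, unknown or untested is made for them only; others in the source may bear on it.

Measured so far:
compound 1, `COc1ccc(-c2cc3ccccc3nc2/C=C/C(=O)c2ccccc2)cc1`: 4040 nM
compound 2, `COc1ccc(-c2cc3ccccc3nc2/C=C/C(=O)c2ccc(O)cc2)cc1`: 6710 nM
compound 3, `COc1ccc(-c2cc3ccccc3nc2/C=C/C(=O)c2ccc(OC)c(OC)c2)cc1`: 6030 nM

All three numbers come from a functional assay on MCF7 cells (Homo sapiens) for antiproliferative activity, read by XTT assay, with a stated time of 72 h; on this read-out higher numbers stand for weaker inhibition and lower numbers for stronger inhibition. Compound 3 stands second highest of the three; its nearest neighbour is compound 2, with a 1.1-fold lower number from compound 2 to compound 3 (0.05 log units; within the scatter), and the furthest is compound 1, with a 1.5-fold higher number from compound 1 to compound 3 (0.17 log units; within the scatter), so the three compounds sit together inside the scatter and no order can be read among them.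

Compound 4, `COc1ccc(-c2cc3ccccc3nc2/C=C/C(=O)c2ccccn2)cc1`, is the next entry. It differs from compound 3 by pyridin-2-yl in place of 3,4-dimethoxyphenyl on a carbonyl carbon.

Two measured steps alter the same aryl group on the carbonyl carbon and therefore bear on this change: a 1.5-fold higher number from compound 1 to compound 3 (0.17 log units; within the scatter) and a 1.1-fold lower number from compound 2 to compound 3 (0.05 log units; within the scatter). The third step, a 1.7-fold higher number from compound 1 to compound 2 (0.22 log units; within the scatter), also changes the substitution on that ring. None of the three moved beyond the scatter, so the aryl group on the carbonyl carbon has so far been a tolerant position across compounds 1, 2 and 3. Pyridin-2-yl has not been tried in this series, but on the evidence of those steps no step beyond the scatter is expected in this assay for compound 4, and the estimated step is a 1.2-fold lower number from compound 3 to compound 4 (0.08 log units; within the scatter).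

Compound 4 is therefore expected to give about 5000 nM in this assay, with a range from 2200 nM to 12000 nM.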

Compound 4, half-maximal inhibitory concentration: 810 nM
For compound 4 the middle estimate is 6.2-fold (0.79 log units) above the measured one; the whole stated range lies above it.
By their numbers in this assay, from the lowest: compound 4; then compounds 1, 3 and 2 (each within the scatter of the next).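

In this assay, the aryl group on the carbonyl carbon no longer looks like a tolerant position: pyridin-2-yl brings a 7.4-fold lower number from compound 3 to compound 4 (0.87 log units; beyond the scatter), and the comparisons with the other two aryl groups give an 8.3-fold lower number from compound 2 to compound 4 (0.92 log units; beyond the scatter) and a 5.0-fold lower number from compound 1 to compound 4 (0.70 log units; beyond the scatter), all beyond the scatter. Phenyl, 4-hydroxyphenyl and 3,4-dimethoxyphenyl, each with a ring of carbon only, remain within the scatter of one another, whereas the one ring with a hetero atom separates from all three, making compound 4 the most potent of the four in this read-out, though this rests on a single compound. Nothing available accounts for this separation.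

From the compounds shown here alone, it remains open whether the lower number belongs to pyridin-2-yl alone or extends to other nitrogen-containing rings on the same carbonyl carbon, such as pyrimidinyl or thiazolyl, and whether a pyridin-2-yl ring carrying an added methoxy or amine keeps it. Also open, going by these compounds, is whether the separation of compound 4 from the other three holds in cells other than those of this single read-out.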